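Fluoro-to-chloro swap on a second core of the series

The source may hold more compounds than are shown below. What is called first, only, known or untested is meant among the compounds shown, and "the series" means these compounds.

Compound 1 `O=C(Nc1ccc(Oc2ccnc3[nH]ccc23)cc1)c1cn(-c2ccc(F)cc2)c2ccccc2c1=O` and compound 2 `O=C(Nc1ccc(Oc2ccnc3[nH]ccc23)cc1)c1cn(-c2ccc(Cl)cc2)c2ccccc2c1=O` share one core; compound 3 `Cn1ccc2c(Oc3ccc(NC(=O)c4cn(-c5ccc(F)cc5)c5ccccc5c4=O)cc3F)ccnc21` and compound 4 `Cn1ccc2c(Oc3ccc(NC(=O)c4cn(-c5ccc(Cl)cc5)c5ccccc5c4=O)cc3F)ccnc21` share another. The difference between the two cores is not broken down here. In a functional assay on A549 cells (Homo sapiens) for inhibition, read by MTT assay, with a stated time of 72 h (a lower number here means a stronger inhibitor, a higher number a weaker inhibitor), compound 1 gives 390 nM, and compound 2 gives 650 nM. The change chloro in place of fluoro on an aromatic carbon made a step of a 1.7-fold higher number from compound 1 to compound 2 (0.22 log units; within the scatter). In this assay compound 3 gives 1460 nM, the highest of the three values. Compound 4 carries the same change, (chloro in place of fluoro on an aromatic carbon), on the other core. Because the earlier step of a 1.7-fold higher number from compound 1 to compound 2 (0.22 log units; within the scatter) stayed within the scatter, the expected step from compound 3 to compound 4 is a 1.7-fold higher number from compound 3 to compound 4 (0.23 log units; within the scatter), of similar size. Compound 4 is accordingly expected to give about 2500 nM in this assay, with a likely span from 1200 nM to 5500 nM.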

Compound 4, half-maximal inhibitory concentration: 250 nM
Compound 4: the middle estimate sits 10-fold (1.00 log units) above what was measured; measured number outside the range, below it.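

In this assay, the change from 4-fluorophenyl to 4-chlorophenyl gives a 5.8-fold lower number from compound 3 to compound 4 (0.77 log units; beyond the scatter), so on this core chloro gives the stronger inhibitor. The change does not carry over from one core to the other with the same size or direction: the same change on two cores in this assay, a 1.7-fold higher number (0.22 log units; within the scatter) from compound 1 to compound 2 and a 5.8-fold lower number (0.77 log units; beyond the scatter) from compound 3 to compound 4, 9.7-fold (0.99 log units) apart, beyond the scatter of two such steps. With a single pair on each core, the result shows that the step depends on the core, but not which part of the difference between the cores is responsible.

Open, going by these compounds, is whether a bromo or a methoxy group in the same place would follow the chloro or the fluoro result on each core. Also open, on these data alone, is how the change behaves on a core carrying only part of the difference between the two cores.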